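Swapping sulfanyl for hexylamino on a nucleoside core

This account rests on a few compounds, and the source may have more. Where it says the series, first, only, none or still open, it means among the compounds named here.

Of the compounds shown here, two have been measured so far in a functional assay (Homo sapiens) for inhibition of Nucleic Acid, tested at 100 uM; on this read-out higher numbers stand for more inhibition at the one concentration tested (going by the name of the read-out) and lower numbers for less inhibition. Compound 1 `OC[C@H]1O[C@@H](n2cnc3c(NCc4ccccc4)nccc32)C[C@@H]1O` carries a benzylamino group on its core, and in this assay compound 1 gives 15%. Compound 2 `OC[C@H]1OC(n2cnc3c(S)nccc32)[C@H](O)[C@@H]1O` carries a sulfanyl group instead and a fully hydroxylated sugar, and in this assay compound 2 gives 6%. These two numbers lie within the usual scatter of repeated measurements of each other, so on this evidence the two numbers are level. For the measured compounds named here, the two also differ in more than one place, so no single step between them can be read off.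

Compound 3 `CCCCCCNc1nccc2c1ncn2C1O[C@H](CO)[C@@H](O)[C@H]1O` keeps the sugar of compound 2 and changes only the group on the aromatic carbon: hexylamino in place of sulfanyl on an aromatic carbon. Because compound 1, with a benzylamino group at a comparable position, gives 15%, a modest rise is expected, though one that may well remain within the scatter. The expected step from compound 2 to compound 3 in this assay is a number 8 percentage points higher from compound 2 to compound 3 (within the scatter). Compound 3 is therefore estimated at 14%, with a range from 2% to 30%.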

Compound 3, a percentage reported as inhibition, at one concentration (the size of the read-out at that concentration, not a potency): 8%
Compound 3: middle estimate off by 6 percentage points, on the high side; low and high end bracket the measured number.
By their numbers in this assay, from the lowest: compounds 2, 3 and 1 (each within the scatter of the next).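

In this assay, hexylamino in place of sulfanyl on an aromatic carbon, next to the ring nitrogen, gives a number 2 percentage points higher from compound 2 to compound 3 (within the scatter). For the compounds shown here, this is the first comparison here in which the two compounds differ in only one place, so it isolates this position in a way the pairing of compound 1 with compound 2 could not: a group of 1 heavy atom gives way to a chain-bearing group of 7 heavy atoms, with the same count of hydrogen-bond donors and acceptors, and the two numbers stay level on this evidence. No measurement available here bears on why this is so.

Going by these compounds, it remains open whether a different group on this aromatic carbon, such as a butylamino or octylamino chain, a carboxylic acid or a plain amine, would give a step beyond the scatter. The compounds shown also leave open how much the sugar contributes, since compound 1 differs from compound 3 in both its sugar and its group on the aromatic carbon, and a benzylamino group on the sugar of compound 3 would separate the two.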